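A few compounds are considered here, and "the series" means these few. Any claim that something is new, unique, unknown or untested is made for them only; others in the source may bear on it.

Compound 3 `CC(C)N(Cc1cccc(OCCCCCC(=O)O)c1)C(=O)c1ccc(-c2ccc3cc[nH]c3c2)cc1` belongs to a small set of close relatives that share one core and differ only in the group attached to an aromatic carbon. In an ADME assay on Raji cells (Homo sapiens) for cytotoxicity, read by CellTiter-Glo and resazurin assay, with a stated time of 72 h (a higher number here means that more compound is needed for the effect, a lower number that less compound is needed), compound 3 gives > 26000 nM, which is a limit of the assay rather than a number. Compound 1 `CC(C)N(Cc1cccc(OCCCCCC(=O)O)c1)C(=O)c1ccc(-c2cccc3ccccc23)cc1` carries a naphthalen-1-yl group at that position, and compound 1 gives > 26000 nM, again a limit. Compound 2 `CC(=O)Nc1cccc(-c2ccc(C(=O)N(Cc3cccc(OCCCCCC(=O)O)c3)C(C)C)cc2)c1` carries a 3-acetamidophenyl group, and compound 2 gives > 26000 nM, also a limit. Because (the limit of > 26000 nM in this assay, at which 3 of the 3 values shown sit), the steps a step that the two limits leave unreadable from compound 1 to compound 2, a step that the two limits leave unreadable from compound 1 to compound 3 and a step that the two limits leave unreadable from compound 2 to compound 3 have no readable size. Compound 4 `COc1cc(F)cc(-c2ccc(C(=O)N(Cc3cccc(OCCCCCC(=O)O)c3)C(C)C)cc2)c1` is the next member of the set: 3-fluoro-5-methoxyphenyl in place of 1H-indol-6-yl on an aromatic carbon. Every measured step that bears on this change ends in a limit, so nothing in the numbers points to a rise or a fall. The step that the limit leaves unreadable from compound 3 to compound 4 is expected to stay at the limit as well. Compound 4 is therefore estimated at 40000 nM, within 15000 nM to 150000 nM, and most likely reported only as a limit.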

Compound 4, half-maximal effective concentration: > 26000 nM
Compound 4: only a limit was reported; the forecaster's own chance of this, stated with the estimate: 85%; the middle value lies beyond the limit too.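

Compound 4 gives > 26000 nM, again a limit and not a number. Within the data shown here, no step linking compound 4 with compound 1, compound 2 or compound 3 can be read, because all four stop at the same limit: the limit of > 26000 nM in this assay, at which 4 of the 4 values shown sit. The compounds shown leave open whether any group at this position changes the concentration needed for the effect.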